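The compounds below may be only part of what the source reports. "The series", "measured", "known", "first", "only" and "open" are said of these compounds alone.

Measured in an assay for displacement of a labelled ligand from Sigma non-opioid intracellular receptor 1 (Cavia porcellus), read by scintillation counting, with a stated time of 180 min; a higher number here means a weaker inhibitor, a lower number a stronger inhibitor:
Compound 1 `COC1Cc2c(cnn2-c2ccccc2)C2(CCNCC2)O1`: > 1000 nM, a limit of the assay rather than a number.
Compound 2 `COC1Cc2c(cnn2-c2ccccc2)C2(CCN(C(C)C)CC2)O1`: 210 nM
Compound 3 `COC1Cc2c(cnn2-c2ccccc2)C2(CCN(CC(C)C)CC2)O1`: 6.3 nM

Compound 3 stands lowest of the two numbers read, its nearest neighbour being compound 2, with a 33-fold lower number from compound 2 to compound 3 (1.52 log units; beyond the scatter) between them. Compound 4 `CCCCCN1CCC2(CC1)OC(OC)Cc1c2cnn1-c1ccccc1` differs from compound 3 by butyl in place of isopropyl on a saturated chain carbon bound to an amine nitrogen in a ring. Within the data shown here, the steps that bear on this change are an at least 4.7-fold lower number from compound 1 to compound 2 (0.67 log units; beyond the scatter), an at least 150-fold lower number from compound 1 to compound 3 (2.20 log units; beyond the scatter) and a 33-fold lower number from compound 2 to compound 3 (1.52 log units; beyond the scatter), each on the same amine nitrogen in the ring; every enlargement of that group so far lowered the number. Butyl is a chain of a new shape, so the step of a 1.3-fold lower number from compound 3 to compound 4 (0.10 log units; within the scatter) is expected to be small. Compound 4 is therefore estimated at 5 nM, within 1.5 nM to 20 nM.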

Compound 4, inhibition constant: 0.82 nM
Beside the measured number, compound 4's estimate is 6.1-fold (0.79 log units) above it; the whole stated range lies above it.
By their numbers in this assay, from the lowest: compound 4; then compound 3; then compound 2. At a limit, above all of these: compound 1.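

In this assay, the gain on the amine nitrogen in the ring does not stop at isobutyl: going from isobutyl to pentyl gives a 7.7-fold lower number from compound 3 to compound 4 (0.89 log units; beyond the scatter). So far, each larger group on that nitrogen has lowered the number, and no compound shown goes against this, with a 260-fold lower number from compound 2 to compound 4 (2.41 log units; beyond the scatter) and an at least 1200-fold lower number from compound 1 to compound 4 (3.08 log units; beyond the scatter). The last of these steps rests on a limit for compound 1, not a number: the limit of > 1000 nM in this assay, at which 1 of the 4 values shown sits.

From the compounds shown here alone, whether a longer chain such as hexyl would lower the number further remains open. So does whether a benzyl group on that nitrogen would follow the same trend.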